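Swapping 3-fluorophenyl for butyl: expected clearance

The source may hold more compounds than are shown below. What is called first, only, known or untested is meant among the compounds shown, and "the series" means these compounds.

Three compounds share one core and differ only in the group on a saturated chain carbon bound to a carbonyl carbon and an oxygen on a saturated carbon. In an ADME assay on liver for metabolic stability, with Liver microsome (Homo sapiens) as the target, read by LC-MS, using microsomes (a lower number here means slower removal, a higher number faster removal of the compound), compound 1 `O=C(NCc1cc(Cl)ccc1-n1cnnn1)[C@@H]1C[C@H]2C[C@H]2N1C(=O)[C@H](O)CC1CC1` gives 25 mL.min-1.g-1, compound 2 `CC(C)(C)[C@@H](O)C(=O)N1[C@@H]2C[C@@H]2C[C@H]1C(=O)NCc1cc(Cl)ccc1-n1cnnn1` gives 54 mL.min-1.g-1 and compound 3 `O=C(NCc1cc(Cl)ccc1-n1cnnn1)[C@@H]1C[C@H]2C[C@H]2N1C(=O)[C@H](O)c1cccc(F)c1` gives 32 mL.min-1.g-1. Compound 3 thus lies within the scatter of both other compounds, with a 1.3-fold higher number from compound 1 to compound 3 (0.11 log units; within the scatter) on one side and a 1.7-fold lower number from compound 2 to compound 3 (0.23 log units; within the scatter) on the other.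

The next compound, compound 4 `CCCC[C@@H](O)C(=O)N1[C@@H]2C[C@@H]2C[C@H]1C(=O)NCc1cc(Cl)ccc1-n1cnnn1`, has not yet been measured. It carries butyl in place of 3-fluorophenyl at that same place (butyl in place of 3-fluorophenyl on a saturated chain carbon bound to a carbonyl carbon and an oxygen on a saturated carbon). For the measured compounds named here, no measured compound has butyl, so the three swaps already made there are the only guide. Both swaps involving 3-fluorophenyl stayed within the scatter and pointed in opposite directions, and the largest swap, a 2.2-fold higher number from compound 1 to compound 2 (0.33 log units; beyond the scatter), only just cleared it. These steps suggest no clear direction, and no change beyond the scatter is expected in this assay. The expected step is a 1.2-fold higher number from compound 3 to compound 4 (0.07 log units; within the scatter). For compound 4 the estimated value is 38 mL.min-1.g-1, with an expected range from 20 mL.min-1.g-1 to 72 mL.min-1.g-1.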

Compound 4, intrinsic clearance in microsomes: 89 mL.min-1.g-1
Estimate against measurement, compound 4: 2.3-fold (0.37 log units) below; measured number outside the range, above it.
By their numbers in this assay, from the lowest: compounds 1, 3, 2 and 4 (each within the scatter of the next, the first and the last beyond it).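

In this assay, this position proves able to move the number beyond the scatter in a way the earlier swaps barely hinted at: butyl in place of 3-fluorophenyl gives a 2.8-fold higher number from compound 3 to compound 4 (0.44 log units; beyond the scatter). The same holds against the other ring-bearing group, since propyl in place of cyclopropyl, on a saturated chain carbon, two bonds along the chain from a carbonyl carbon and an oxygen on a saturated carbon, gives a 3.6-fold higher number from compound 1 to compound 4 (0.55 log units; beyond the scatter), the widest step in the set. Among these four compounds, the two with a ring in this group, compound 1 and compound 3, each lie beyond the scatter from butyl, but a simple split between ring and no ring fails on compound 2, whose tert-butyl group has no ring and yet sits within the scatter of compound 3 as well as of butyl, with a 1.6-fold higher number from compound 2 to compound 4 (0.22 log units; within the scatter).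

The data shown offer no independent measurement that explains these differences. On these data alone, it remains open whether a longer chain would raise the number further, and whether an amine or a carboxylic acid at the end of the butyl chain would bring it back down.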